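Lengthening the Amine Side Chain of a Vitamin D Receptor Agonist

A few compounds are considered here, and "the series" means these few. Any claim that something is new, unique, unknown or untested is made for them only; others in the source may bear on it.

Compound 1 `CCn1cc(C(CC)(CC)c2ccc(C#CC(O)(CC)CC)c(C)c2)cc1C(=O)NCC(=O)OC` gives 288 nM in an assay on cells for agonist activity at vitamin D3 receptor (Homo sapiens), read by microscopy; on this read-out lower numbers stand for an effect already at smaller amounts and higher numbers for an effect only at larger amounts of compound.
Compound 2 `CCN(CC)CCNC(=O)c1cc(C(CC)(CC)c2ccc(C#CC(O)(CC)CC)c(C)c2)cn1CC` gives 6.98 nM in this assay.
Compound 3 `CCn1cc(C(CC)(CC)c2ccc(C#CC(O)(CC)CC)c(C)c2)cc1C(=O)NCCN(C)C` gives 19.3 nM in this assay.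

Compound 3 stands second highest of these three numbers: it shows a 15-fold lower number from compound 1 to compound 3 (1.17 log units; beyond the scatter), yet also a 2.8-fold higher number from compound 2 to compound 3 (0.44 log units; beyond the scatter). Compound 4 `CCn1cc(C(CC)(CC)c2ccc(C#CC(O)(CC)CC)c(C)c2)cc1C(=O)NCCCN(C)C` differs from compound 3 by (dimethylamino)methyl in place of dimethylamino on a saturated chain carbon, two bonds along the chain from an amide-type nitrogen. Among the measured compounds shown here, no measured step lengthens this side chain itself; the nearest comparison is a 2.8-fold higher number from compound 2 to compound 3 (0.44 log units; beyond the scatter), a modest shift at the same place, while a 41-fold lower number from compound 1 to compound 2 (1.62 log units; beyond the scatter) shows that the amine matters far more than its details. One added carbon is therefore expected to move the value only a little, if at all beyond the scatter: a 1.3-fold lower number from compound 3 to compound 4 (0.11 log units; within the scatter). Compound 4 is estimated at 15 nM, with a likely range from 5 nM to 50 nM.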

Compound 4, half-maximal effective concentration: 142 nM
The estimate for compound 4 lay 9.5-fold (0.98 log units) below the measured number; the whole stated range lies below it.
By their numbers in this assay, from the lowest: compound 2; then compound 3; then compound 4; then compound 1.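

Lengthening 2-(dimethylamino)ethyl to 3-(dimethylamino)propyl is no minor detail in this assay: it gives a 7.4-fold higher number from compound 3 to compound 4 (0.87 log units; beyond the scatter). The longer chain also falls well short of the diethylamino compound, with a 20-fold higher number from compound 2 to compound 4 (1.31 log units; beyond the scatter), and keeps only a small gain over the methoxycarbonyl compound, with a 2.0-fold lower number from compound 1 to compound 4 (0.31 log units; beyond the scatter), so among these compounds an amine alone is not enough and chain length counts too. Nothing available explains why this extension costs so much.

Still open, as far as these compounds go, is how a longer chain, such as 4-(dimethylamino)butyl, would behave. Also open, from the compounds shown here alone, is whether diethylamino on the 3-carbon chain would show the same loss.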